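Ethyl on the Aromatic Ring of Compound 1

The compounds below may be only part of what the source reports. "The series", "measured", "known", "first", "only" and "open" are said of these compounds alone.

In a functional assay on HL-60 cells (Homo sapiens) for cytotoxicity, read by WST assay, with a stated time of 48 h (on this read-out lower numbers stand for an effect already at smaller amounts and higher numbers for an effect only at larger amounts of compound), compound 1 `Clc1ccc(C[C@H]2COC[C@@H]2Cc2ccccc2)cc1Cl` gives 19000 nM and shares the low end of the three measured numbers with compound 2 `CCCCOc1ccccc1C[C@H]1COC[C@@H]1Cc1ccc(Cl)c(Cl)c1` at 20000 nM in the same test. Compound 3 `COc1cccc(C[C@H]2COC[C@@H]2Cc2ccc(Cl)c(Cl)c2)c1` stands higher at 73000 nM in this set.

Compound 4 `CCc1ccc(C[C@H]2COC[C@@H]2Cc2ccc(Cl)c(Cl)c2)cc1` has not yet been measured. Its difference from compound 1 is ethyl in place of hydrogen on an aromatic carbon and it lies on an aromatic carbon of a six-membered aromatic ring of carbon only, para to a large group.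

Among the measured compounds shown here, two measured steps bear on this change, as each also replaces hydrogen on an aromatic carbon. Butoxy gave a 1.1-fold higher number from compound 1 to compound 2 (0.02 log units; within the scatter) and methoxy gave a 3.8-fold higher number from compound 1 to compound 3 (0.58 log units; beyond the scatter) in these measurements. Neither step brings ethyl, and the two differ in size, which supports only a small expected rise in this assay and probably none beyond the scatter.

The estimated step is a 1.6-fold higher number from compound 1 to compound 4 (0.20 log units; within the scatter) on this evidence. Compound 4 is expected at 30000 nM with an estimated range from 12000 nM to 80000 nM when measured.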

Compound 4, half-maximal effective concentration: 26000 nM
For compound 4 the middle estimate is 1.2-fold (0.06 log units) above the measured one; the measured number falls inside the stated range.
By their numbers in this assay, from the lowest: compounds 1, 2 and 4 (each within the scatter of the next); then compound 3.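

In this assay, ethyl on an aromatic carbon para to a large group gives a 1.4-fold higher number from compound 1 to compound 4 (0.14 log units; within the scatter), so this carbon accepts a small group made of carbon only with no change beyond the scatter. Ethyl therefore joins butoxy, which gives a 1.1-fold higher number from compound 1 to compound 2 (0.02 log units; within the scatter), as a replacement of hydrogen on an aromatic carbon that leaves the number within the scatter, while methoxy goes against this pattern with a 3.8-fold higher number from compound 1 to compound 3 (0.58 log units; beyond the scatter). Nothing measured here accounts for the difference between these steps. The compounds shown leave open whether a longer chain such as butyl at this same carbon would also leave the number within the scatter. They also leave open how an amine or a carboxylic acid would behave there.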